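Hydroxy to methoxy on the saturated ring carbon

A few compounds are considered here, and "the series" means these few. Any claim that something is new, unique, unknown or untested is made for them only; others in the source may bear on it.

Measured in a functional assay for inhibition, with Homo sapiens as the target; a lower number here means a stronger inhibitor, a higher number a weaker inhibitor:
- compound 1 `Cc1cc2c(cc1C(=O)N=C(N)N)S(=O)(=O)CC2C(C)C`: 77 nM
- compound 2 `Cc1cc2c(cc1C(=O)N=C(N)N)S(=O)(=O)CC2N`: 692 nM
- compound 3 `Cc1cc2c(cc1C(=O)N=C(N)N)S(=O)(=O)CC2O`: 1050 nM

Compound 3 stands level with compound 2, with a 1.5-fold higher number from compound 2 to compound 3 (0.18 log units; within the scatter). The gap to the isopropyl member is wider, with a 14-fold higher number from compound 1 to compound 3 (1.13 log units; beyond the scatter).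

Compound 4 `COC1CS(=O)(=O)c2cc(C(=O)N=C(N)N)c(C)cc21` carries methyl in place of hydrogen on an oxygen on a saturated carbon, which turns hydroxy to methoxy. Going by the values given here, no measured step makes this exact change. The closest guides are a 9.0-fold higher number from compound 1 to compound 2 (0.95 log units; beyond the scatter) and the two steps above. Only compound 1, at 77 nM, sits clearly lower, so a modest move towards it is expected in this assay. The expected step is a 1.9-fold lower number from compound 3 to compound 4 (0.28 log units; within the scatter). For compound 4 the estimated value is 550 nM, with an expected range of 220 nM to 1300 nM.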

Compound 4, half-maximal inhibitory concentration: 208 nM
Compound 4: the middle estimate sits 2.6-fold (0.42 log units) above what was measured; the whole stated range lies above it.
By their numbers in this assay, from the lowest: compound 1; then compound 4; then compounds 2 and 3 (each within the scatter of the next).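

In this assay the methyl on the oxygen counts at this position (a 5.0-fold lower number from compound 3 to compound 4 (0.70 log units; beyond the scatter)), whereas amino and hydroxy had stayed within the scatter of each other. Methoxy also separates from amino (a 3.3-fold lower number from compound 2 to compound 4 (0.52 log units; beyond the scatter)) but stays short of isopropyl (a 2.7-fold higher number from compound 1 to compound 4 (0.43 log units; beyond the scatter)), so the saturated ring carbon distinguishes among small groups more finely than the earlier compounds showed. No evidence is available that accounts for these steps. Open, as far as these compounds go, is whether ethoxy, a longer chain on the oxygen, would close the remaining gap to isopropyl, and how a carboxylic acid on this carbon would compare.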